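Quinazoline series: anilino variants and the cytotoxicity limit

The source may report more compounds than this note shows. Statements on the series, on what has been measured and on what is new or still open speak of the compounds shown alone.

Compound 1 `CCCCCCCCNc1nc(SCc2ccc(C(F)(F)F)cc2)nc2ccccc12` gives 12600 nM in a functional assay on MGC-803 cells (Homo sapiens) for cytotoxicity, read by MTT assay, with a stated time of 72 h; a lower number here means a stronger inhibitor, a higher number a weaker inhibitor. Compound 2 `FC(F)(F)c1ccc(CSc2nc(N3CCCCC3)c3ccccc3n2)cc1` gives 18600 nM in this assay, and a 1.5-fold higher number from compound 1 to compound 2 (0.17 log units; within the scatter). Compound 3 `FC(F)(F)c1ccc(CSc2nc(Nc3ccccc3Cl)c3ccccc3n2)cc1` reaches only the limit of this assay, > 50000 nM, so for compound 3 the shown figure is a limit and not a number (the limit of > 50000 nM in this assay, at which 1 of the 3 values shown sits). Against the two alkyl-type amines the arylamino member sits weaker: an at least 3.9-fold higher number from compound 1 to compound 3 (0.59 log units; beyond the scatter), and an at least 2.6-fold higher number from compound 2 to compound 3 (0.42 log units; beyond the scatter). Compound 4 `COc1ccccc1Nc1nc(SCc2ccc(C(F)(F)F)cc2)nc2ccccc12` differs from compound 3 by methoxy in place of chloro on an aromatic carbon, ortho to a large group. Among the measured compounds shown here, no measured step exchanges one substituent on that aryl ring for another; the steps from compound 1 and compound 2 to compound 3 only place the (2-chlorophenyl)amino member at the limit. For the measured compounds named here, with no step bearing on the chloro-to-methoxy exchange, no change beyond the scatter is expected, so compound 4 is expected to sit near the same limit, a number no higher from compound 3 to compound 4 (the limit leaves the size open). Compound 4 is estimated at 50000 nM, with a range from 20000 nM to 120000 nM, and a limit reading is the likely outcome.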

Compound 4, half-maximal inhibitory concentration: > 50000 nM
Compound 4: only a limit was reported (the forecaster's own chance of this, stated with the estimate: 60%); the middle value lies on the limit itself.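

With methoxy in place of chloro, a second arylamino member sits at the limit of this assay, so the reading at this position does not depend on chloro alone: compound 4 gives > 50000 nM, which is a limit and not a number. Compound 4 repeats the gap already seen for compound 3 against the two alkyl-type amines: an at least 2.6-fold higher number from compound 2 to compound 4 (0.42 log units; beyond the scatter), and an at least 3.9-fold higher number from compound 1 to compound 4 (0.59 log units; beyond the scatter). The step between compound 3 and compound 4 cannot be read, so the chloro-to-methoxy exchange has no size here, and the limit now holds more of the series: the limit of > 50000 nM in this assay, at which 2 of the 4 values shown sit.

As far as these compounds go, how far compound 3 and compound 4 lie past the limit, and whether they differ at all, stays open. Also open, from the compounds shown here alone, is whether a carboxylic acid or an amine in the same place on the aromatic ring would bring an arylamino member to a readable number.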